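Swapping fluorine for bromine on a shorter linker

A few compounds are considered here, and "the series" means these few. Any claim that something is new, unique, unknown or untested is made for them only; others in the source may bear on it.

Three compounds share a layout in which two ring systems are joined through a chain, and all three were tested in a functional assay on THP-1 cells (Homo sapiens) for inhibition, read by sulforhodamine B assay, with a stated time of 48 h, tested at 50 uM; a lower number here means less inhibition of growth, a higher number more inhibition of growth at the concentration tested. Compound 3 `O=C1C(=O)N(CCCCn2cc(COc3cc(=O)oc4ccccc34)nn2)c2ccc(F)cc21` carries a fluoro group and gives 77%. Compound 1 `O=C1C(=O)N(CCCCn2cc(COc3cc(=O)oc4ccccc34)nn2)c2ccc(Br)cc21` carries a bromo group in place of that fluoro group and gives 63%; the step of a number 14 percentage points lower from compound 3 to compound 1 (beyond the scatter) records this change, and its counted form is bromo in place of fluoro on an aromatic carbon. Compound 2 `O=C1C(=O)N(CCCn2cc(COc3cc(=O)oc4ccccc34)nn2)c2ccc(F)cc21` keeps the fluoro group but has a shorter chain than compound 3; how the two cores differ is not broken down here. In this assay compound 2 gives 86%, which lies within the scatter of the number for compound 3, while the number for compound 1 sits clearly lower than that of compound 2.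

Compound 4 `O=C1C(=O)N(CCCn2cc(COc3cc(=O)oc4ccccc34)nn2)c2ccc(Br)cc21` has not yet been measured. It differs from compound 2 by bromo in place of fluoro on an aromatic carbon, the same change as from compound 3 to compound 1, at a place described in the same words. Because the earlier change gave a number 14 percentage points lower from compound 3 to compound 1 (beyond the scatter), a step of similar size is expected here, a number 14 percentage points lower from compound 2 to compound 4 (beyond the scatter). This expectation rests on a single pair, so its range is kept wide. Compound 4 is therefore estimated to give 72% in this assay, expected to fall between 60% and 84%.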

Compound 4, percent growth inhibition at one concentration: 72%
Compound 4: the middle estimate sits on the measured number at the digits printed; the range from low to high includes it.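

On the core with the shorter chain, bromo in place of fluoro on an aromatic carbon gives a number 14 percentage points lower from compound 2 to compound 4 (beyond the scatter) in this assay. Set beside the earlier step, the change carries over from one core to the other with no difference in size that stands out from the scatter: the same change on two cores in this assay, a number 14 percentage points lower (beyond the scatter) from compound 3 to compound 1 and a number 14 percentage points lower (beyond the scatter) from compound 2 to compound 4, 0 percentage points apart, within the scatter of two such steps What this does not show is why the number falls, or whether the same step would appear on a core that differs by more than the length of its chain, since the evidence amounts to two pairs of close relatives, read in one assay at one concentration, and growth inhibition at a single concentration gives no full picture of how the compounds behave across a range of doses.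

The compounds shown carry only fluoro or bromo at this place, so it remains open whether chloro, methoxy, an amine or a nitrile on the same aromatic carbon would fall in line with these two steps. As far as these compounds go, it also remains open whether the step keeps its size with a longer chain, or with something other than a plain chain joining the two ring systems.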